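Sulfonyl aryl variation and liver microsomal clearance

The compounds below may be only part of what the source reports. "The series", "measured", "known", "first", "only" and "open" are said of these compounds alone.

Measured so far:
compound 1 `COc1ccc(S(=O)(=O)c2cnc3cc(F)ccc3c2-c2ccc(F)cc2)cc1Cl` gives 1.29 mL/min
compound 2 `COc1cccc(S(=O)(=O)c2cnc3cc(F)ccc3c2-c2cccc(F)c2)c1` gives 3.36 mL/min

In an ADME assay on microsomes from liver (Homo sapiens) for metabolic stability, tested at 2.5 uM (on this read-out higher numbers stand for fast clearance and lower numbers for slow clearance), compound 2 stands highest of the two numbers, with compound 1 the nearest at a lower value, and the gap between them lies beyond the scatter. Compound 3 `COc1ccc(S(=O)(=O)c2cnc3cc(F)ccc3c2-c2cccc(F)c2)cc1Cl` is not yet measured. It differs from compound 2 by 3-chloro-4-methoxyphenyl in place of 3-methoxyphenyl on a sulfonyl sulfur. Compound 3 carries the same 3-chloro-4-methoxyphenyl as compound 1, whose value is 1.29 mL/min, so a downward step is expected, a 1.9-fold lower number from compound 2 to compound 3 (0.27 log units; within the scatter), though compound 1 and compound 2 also differ elsewhere. Compound 3 is estimated at 1.8 mL/min, within 1 mL/min to 3.4 mL/min.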

Compound 3, intrinsic clearance in a liver preparation (reported as CLH), per the amount of preparation that the assay uses: 2.08 mL/min
Compound 3: the middle estimate sits 1.2-fold (0.06 log units) below what was measured; the measured number falls inside the stated range.
By their numbers in this assay, from the lowest: compounds 1, 3 and 2 (each within the scatter of the next, the first and the last beyond it).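

In this assay the two changes can now be read one at a time: 3-chloro-4-methoxyphenyl in place of 3-methoxyphenyl on a sulfonyl sulfur gives a 1.6-fold lower number from compound 2 to compound 3 (0.21 log units; within the scatter), and 3-fluorophenyl in place of 4-fluorophenyl on an aromatic carbon gives a 1.6-fold higher number from compound 1 to compound 3 (0.21 log units; within the scatter). Each single change stays within the scatter, while compound 1 and compound 2, which differ in both places, lie beyond it. Nothing available bears on the origin of these steps. As far as these compounds go, whether a morpholine or a carboxylic acid in place of 3-chloro-4-methoxyphenyl on a sulfonyl sulfur would give a step beyond the scatter stays open.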